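A few compounds are considered here, and "the series" means these few. Any claim that something is new, unique, unknown or untested is made for them only; others in the source may bear on it.

Compound 1 `O=[N+]([O-])c1ccc(CN2CCC(n3cc(CC(OCc4cc(-c5ccc(Br)cc5)no4)c4ccc(Br)cc4)nn3)CC2)cc1` gives 4000 nM in a functional assay on MCF7 cells (Homo sapiens) for cytotoxicity, with a stated time of 48 h; on this read-out higher numbers stand for weaker inhibition and lower numbers for stronger inhibition.
Compound 2 `O=[N+]([O-])c1ccc(CN2CCC(n3cc(CC(OCc4cc(-c5ccccc5F)no4)c4ccc(Br)cc4)nn3)CC2)cc1` gives 8000 nM in this assay.

Among the measured compounds shown here, compound 2 stands at the upper end of the two numbers measured so far, although the only step, from compound 1 to compound 2, was a 2.0-fold higher number from compound 1 to compound 2 (0.30 log units; within the scatter), brought about by 2-fluorophenyl in place of 4-bromophenyl on an aromatic carbon. Compound 3 `COc1ccccc1-c1cc(COC(Cc2cn(C3CCN(Cc4ccc([N+](=O)[O-])cc4)CC3)nn2)c2ccc(Br)cc2)on1` has not yet been measured. It differs from compound 2 by methoxy in place of fluoro on an aromatic carbon. For the measured compounds named here, only one measured step bears on this change, and it does so loosely: the step from compound 1 to compound 2 exchanged one whole aryl group for another and still stayed within the scatter, whereas the present change keeps the same aryl ring and replaces one substituent on it. Going by the values given here, nothing among the measured compounds points to a move beyond the scatter in either direction in this assay. Compound 3 is therefore expected to give about 8000 nM, with a range from 3000 nM to 20000 nM. The expected step from compound 2 to compound 3 is no change at the digits printed from compound 2 to compound 3 (within the scatter), that is, no change beyond the scatter.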

Compound 3, half-maximal inhibitory concentration: 3000 nM
For compound 3 the middle estimate is 2.7-fold (0.43 log units) above the measured one, and the stated range covers the measured number.
By their numbers in this assay, from the lowest: compounds 3, 1 and 2 (each within the scatter of the next, the first and the last beyond it).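

In this assay, among the compounds shown here, the exchange of fluoro for methoxy, on an aromatic carbon ortho to a large group, gives a 2.7-fold lower number from compound 2 to compound 3 (0.43 log units; beyond the scatter) and so is the first step to pass beyond the scatter, although it alters only one substituent on the same aryl ring. The 2-methoxyphenyl group of compound 3 and the 4-bromophenyl group of compound 1 cannot be told apart in this read-out, with a 1.3-fold lower number from compound 1 to compound 3 (0.12 log units; within the scatter) lying within the scatter, so among the three compounds only compound 2 and compound 3 are separated. No measurement of any other kind bears on this result, and what lies behind the step remains unexplained.

The compounds shown leave open whether an ethoxy group, a hydroxyl group or an amine on the same aromatic carbon would read like the methoxy of compound 3 or like the fluoro of compound 2. They also leave open whether a 4-methoxyphenyl group would match the 2-methoxyphenyl group, and whether the exchange of fluoro for methoxy would give a comparable step on a core carrying something other than the bromophenyl group.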